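The compounds below may be only part of what the source reports. "The series", "measured", "known", "first", "only" and "open" are said of these compounds alone.

Compound 1 `CC(=O)O[C@]1(C)/C=C/C(=O)/C(CO)=C\C[C@](C)(CCC=C(C)C)/C=C/[C@H]1OC(=O)C=C(C)C`: 3080 nM
Compound 2 `CC(C)=CCC[C@]1(C)/C=C/[C@@H](OC(=O)C=C(C)C)[C@](C)(O)/C=C/C(=O)/C(CN(C)C)=C\C1`: 820 nM
Compound 3 `CC(C)=CCC[C@](C)(/C=C/[C@@H](OC(=O)C=C(C)C)[C@](C)(O)/C=C/C(=O)/C=C/N(C)C)CC=O`: 10300 nM

These values come from a functional assay on SMMC-7721 cells (Homo sapiens) for antiproliferative activity, read by MTT assay, with a stated time of 48 h; a lower number here means a stronger inhibitor, a higher number a weaker inhibitor. Compound 2 shows the lowest number of the three, and its gaps to compound 1 and to compound 3 both lie beyond the usual scatter of repeated measurements, so compound 2 is the strongest inhibitor among them.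

Compound 4 `CC(C)=CCC[C@]1(C)/C=C/[C@@H](OC(=O)C=C(C)C)[C@](C)(O)/C=C/C(=O)/C(C(=O)N2CCCC2)=C\C1` has not yet been measured. It differs from compound 2 in one place: (pyrrolidin-1-yl)carbonyl in place of (dimethylamino)methyl on a double-bonded ring carbon. Within the data shown here, no measured pair shows this exact change, so any expectation rests on how compound 2 stands against the other two. A modest step toward a higher number is expected, a 3.0-fold higher number from compound 2 to compound 4 (0.48 log units; beyond the scatter). Compound 4 is therefore estimated to give 2500 nM, with an expected range from 800 nM to 8000 nM.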

Compound 4, half-maximal inhibitory concentration: 14900 nM
Compound 4: middle estimate off by 6.0-fold (0.78 log units), on the low side; measured number outside the range, above it.
By their numbers in this assay, from the lowest: compound 2; then compound 1; then compounds 3 and 4 (each within the scatter of the next).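

In this assay, putting (pyrrolidin-1-yl)carbonyl in place of (dimethylamino)methyl on the double-bonded ring carbon gives an 18-fold higher number from compound 2 to compound 4 (1.26 log units; beyond the scatter) and so a much weaker inhibitor. This shows that activity here does not rest on the shared core alone: the group at this one position can change the result substantially.

Two things changed at once, the ring and the carbonyl, so (pyrrolidin-1-yl)methyl or (dimethylamino)carbonyl at this position would be needed to tell them apart. Nothing shown here gives a reason for the loss.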